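A few compounds are considered here, and "the series" means these few. Any claim that something is new, unique, unknown or untested is made for them only; others in the source may bear on it.

Compound 1 `CC(=O)C1=C(C)NC(=O)NC1c1ccoc1` gives 6% in an assay on membranes from CHO cells for displacement of a labelled ligand from adenosine receptor A1 (Homo sapiens), read by scintillation counting, with a stated time of 60 min, tested at 1 uM; a higher number here means more inhibition at the concentration tested (going by the name of the read-out), a lower number less inhibition.
Compound 2 `CCC(CC)OC(=O)C1=C(C)NC(=O)NC1c1ccoc1` gives 17% in this assay.

Among the compounds with values here, of the two numbers measured so far, compound 2 stands highest, with compound 1 as its only neighbour at a lower value. Within the data shown here, the one step recorded between them, a number 11 percentage points higher from compound 1 to compound 2 (beyond the scatter), came from putting (pentan-3-yl)oxy in place of methyl on a carbonyl carbon, so it also touches the part of the molecule that now changes.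

Compound 3 `CC1=C(C(=O)OC2CCCC2)C(c2ccoc2)NC(=O)N1` has not yet been measured in this assay. It differs from compound 2 in one place: cyclopentyl in place of pentan-3-yl on an oxygen next to a carbonyl group. Both groups are built from the same count of carbon atoms; the difference is that the new one closes into a five-membered ring while the old one is an open chain.

The measured step shows that swapping a small group for a five-carbon ester group moved the number only modestly. Replacing one five-carbon group by another on the same oxygen is a smaller change than that, so for compound 3 the expected step of no change at the digits printed from compound 2 to compound 3 (within the scatter) is none beyond the scatter. Compound 3 is therefore estimated at 17%, within the range 5% to 30%.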

Compound 3, a percentage reported as inhibition, at one concentration (the size of the read-out at that concentration, not a potency): 6%
Compound 3: middle estimate off by 11 percentage points, on the high side, and the stated range covers the measured number.
By their numbers in this assay, from the lowest: compounds 1 and 3 (each within the scatter of the next); then compound 2.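

Closing the open chain into a ring on an oxygen next to a carbonyl group made a measurable difference in this assay: cyclopentyl in place of pentan-3-yl gives a number 11 percentage points lower from compound 2 to compound 3 (beyond the scatter) and so two groups with the same count of carbon atoms do not behave alike at this position. The earlier step, a number 11 percentage points higher from compound 1 to compound 2 (beyond the scatter), therefore cannot be credited to just any five-carbon group here, since swapping the methyl on the carbonyl carbon for cyclopentyloxy gives no change at the digits printed from compound 1 to compound 3 (within the scatter) and the rise appears only with (pentan-3-yl)oxy among these three compounds. Nothing available explains why the open chain and the ring part ways in this assay.

The compounds shown leave open whether the rise belongs to branched open chains more widely, as a longer chain such as heptan-4-yl or a simple isopropyl group on the same oxygen would help to show. They also leave open whether another ring, such as cyclohexyl or cyclopropyl, would match cyclopentyl or pentan-3-yl, and what an amine or a carboxylic acid carried on that group would do to the number.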